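The compounds below may be only part of what the source reports. "The series", "measured", "known", "first", "only" and "open" are said of these compounds alone.

Working notes on the series, read in an ADME assay on microsomes from liver (Mus musculus) for metabolic stability; on this read-out higher numbers stand for fast clearance and lower numbers for slow clearance. Compound 1 (`Cc1n[nH]c(-c2ncc3cccnc3c2O)n1`) gives 3.3 mL.min-1.g-1 and compound 2 (`CNc1ccnc2c(O)c(-c3nc(C)n[nH]3)ncc12`) gives 3.1 mL.min-1.g-1. Methylamino in place of hydrogen on an aromatic carbon thus gives a 1.1-fold lower number from compound 1 to compound 2 (0.03 log units; within the scatter).

Compound 3 (`Cc1n[nH]c(-c2ncc3c(N4CCCC4=O)ccnc3c2O)n1`) gives < 0.5 mL.min-1.g-1, and this is a limit of the assay, not a number. It is the only one of the three measured compounds reported as a limit.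

The next change leads to compound 4 (`Cc1n[nH]c(-c2ncc3c(-c4ccccc4)ccnc3c2O)n1`), with phenyl in place of 2-oxopyrrolidin-1-yl on an aromatic carbon. Among the compounds with values here, no phenyl compound has been measured, so the size of the step can only be judged from the steps into compound 3. Because of an at least 6.6-fold lower number from compound 1 to compound 3 (0.81 log units; beyond the scatter) and an at least 6.2-fold lower number from compound 2 to compound 3 (0.79 log units; beyond the scatter) a rise of similar size, beyond the scatter, is expected in this assay once the 2-oxopyrrolidin-1-yl is gone.

The estimate for compound 4 means an expected step of an at least 6.0-fold higher number from compound 3 to compound 4 (0.77 log units; beyond the scatter). Compound 4 is estimated at 3 mL.min-1.g-1, with an expected range from 1 mL.min-1.g-1 to 8 mL.min-1.g-1.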

Compound 4, intrinsic clearance in microsomes: 9.4 mL.min-1.g-1
Beside the measured number, compound 4's estimate is 3.1-fold (0.50 log units) below it, outside the stated range (above it).
By their numbers in this assay, from the lowest: compounds 2 and 1 (each within the scatter of the next); then compound 4. At a limit, below all of these: compound 3.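

In this assay, within the data shown here, phenyl in place of hydrogen gives a 2.8-fold higher number from compound 1 to compound 4 (0.45 log units; beyond the scatter) and phenyl in place of methylamino gives a 3.0-fold higher number from compound 2 to compound 4 (0.48 log units; beyond the scatter), so phenyl is the first group here to raise the number over that of compound 1. Phenyl and 2-oxopyrrolidin-1-yl have the same count of heavy atoms, yet phenyl in place of 2-oxopyrrolidin-1-yl gives an at least 18-fold higher number from compound 3 to compound 4 (1.27 log units; beyond the scatter), so the heavy-atom count alone does not set the read-out at this position. The full size of that step cannot be read, because compound 3 stands at a limit of the assay and not at a number: the limit of < 0.5 mL.min-1.g-1 in this assay, at which 1 of the 4 values shown sits.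

These compounds cannot separate the effect of the aromatic ring in phenyl from that of losing the carbonyl of 2-oxopyrrolidin-1-yl. Cyclohexyl, pyridyl or an open-chain acetamide at this position would bear on that question.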